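The source may report more compounds than this note shows. Statements on the series, on what has been measured and on what is new or still open speak of the compounds shown alone.

Working notes on the series. In a functional assay on HepG2 cells (Homo sapiens) for antiproliferative activity, read by MTT assay, with a stated time of 48 h (on this read-out higher numbers stand for weaker inhibition and lower numbers for stronger inhibition), compound 1 (`COc1ccc(/C=C/c2cc(OC)cc(OC)c2/C=C/C(=O)c2ccc(Br)cc2)cc1`) gives 12.9 ug/mL and compound 2 (`COc1ccc(/C=C/c2cc(OC)cc(OC)c2/C=C/C(=O)c2ccc(N)cc2)cc1`) gives 7.5 ug/mL while compound 3 (`COc1ccc(/C=C/c2cc(OC)cc(OC)c2/C=C/C(=O)c2ccc(Cl)cc2)cc1`) gives 13.6 ug/mL on the same read-out. Compound 3 therefore sits within the scatter of both other compounds. The measured steps to it are a 1.1-fold higher number from compound 1 to compound 3 (0.02 log units; within the scatter) for chloro in place of bromo on an aromatic carbon and a 1.8-fold higher number from compound 2 to compound 3 (0.26 log units; within the scatter) for chloro in place of amino on an aromatic carbon. The remaining step, a 1.7-fold lower number from compound 1 to compound 2 (0.24 log units; within the scatter) for amino in place of bromo on an aromatic carbon, also lies within the scatter.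

Next comes compound 4 (`COc1ccc(/C=C/c2cc(OC)cc(OC)c2/C=C/C(=O)c2ccccc2C)cc1`), where the change from compound 3 is 2-methylphenyl in place of 4-chlorophenyl on a carbonyl carbon and reads as 2-methylphenyl in place of 4-chlorophenyl on a carbonyl carbon. Among the measured compounds shown here, the three measured steps bear on this only loosely: each swaps one group on an aromatic carbon, and no measured compound carries 2-methylphenyl. None of them leaves the scatter, so no step beyond the scatter is expected in this assay and no direction can be assigned. The estimated step is a 1.1-fold lower number from compound 3 to compound 4 (0.05 log units; within the scatter) and it is expected to stay within the scatter. For compound 4 the estimated value is 12 ug/mL with an expected range of 5.5 ug/mL to 26 ug/mL in this estimate.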

Compound 4, half-maximal inhibitory concentration: 5.3 ug/mL
Compound 4: middle estimate off by 2.3-fold (0.35 log units), on the high side; the measured number lies below the stated range.
By their numbers in this assay, from the lowest: compounds 4, 2, 1 and 3 (each within the scatter of the next, the first and the last beyond it).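

Among the compounds shown here, on the carbonyl carbon, the aryl exchange gives the first steps beyond the scatter in this assay, both modest: 2-methylphenyl in place of 4-chlorophenyl (a 2.6-fold lower number from compound 3 to compound 4 (0.41 log units; beyond the scatter)) and 2-methylphenyl in place of 4-bromophenyl (a 2.4-fold lower number from compound 1 to compound 4 (0.39 log units; beyond the scatter)). The same exchange against 4-aminophenyl stays within the scatter (a 1.4-fold lower number from compound 2 to compound 4 (0.15 log units; within the scatter)), so the change does not read the same against every group leaving, and compound 2 and compound 4 cannot be told apart on this read-out. No measurement shown accounts for these steps, so the data give no reason for the difference.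

Each of these steps changes both the substituent and the place where it sits on the ring, so the two contributions cannot be separated; a 4-methylphenyl or a 2-chlorophenyl group on the same carbonyl carbon would divide them. From the compounds shown here alone, whether the substituent is needed at all stays open too, as does the outcome for a plain phenyl group or a 2-methoxyphenyl group on the shared core.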